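Swapping trifluoromethyl for phenoxy on a weak pyrazole series

The compounds below may be only part of what the source reports. "The series", "measured", "known", "first", "only" and "open" are said of these compounds alone.

Measured so far:
compound 1, `Cc1n[nH]c(C(=O)O)c1Cc1ccc2ccccc2n1`: 2%
compound 2, `Cc1n[nH]c(C(=O)O)c1Cc1ccc(C(F)(F)F)cc1`: 9%
compound 3, `Cc1n[nH]c(C(N)=O)c1Cc1cccc(-c2ccc(F)cc2)c1`: 1%

All three compounds were tested in an assay on isolated protein for inhibition of 2-Hydroxyacid oxidase 2 (Homo sapiens), tested at 1 uM; a higher number here means a stronger effect of the compound at the concentration tested, a lower number a weaker effect. For the measured compounds named here, compound 2 shows the highest of the three numbers, yet its gaps to compound 1 and to compound 3 both lie within the usual scatter, so no compound stands apart and all three read as weak.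

The next compound, compound 4 `Cc1n[nH]c(C(=O)O)c1Cc1ccc(Oc2ccccc2)cc1`, differs from compound 2 in one place: phenoxy in place of trifluoromethyl on an aromatic carbon. Going by the values given here, no measured pair here shows the effect of such a change, so nothing supports a shift in either direction; the expected step of a number 1 percentage points lower from compound 2 to compound 4 (within the scatter) is none beyond the scatter. Compound 4 is therefore estimated at 8%, within a range of 0% to 25%.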

Compound 4, a percentage reported as inhibition, at one concentration (the size of the read-out at that concentration, not a potency): 10%
For compound 4 the middle estimate is 2 percentage points below the measured one; measured number inside the range.
By their numbers in this assay, from the lowest: compounds 3, 1, 2 and 4 (each within the scatter of the next).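

Putting phenoxy in place of trifluoromethyl gives a number 1 percentage points higher from compound 2 to compound 4 (within the scatter) in this assay. The swap adds an aromatic ring and a hydrogen-bond acceptor on this aromatic carbon, yet the read-out does not move beyond the scatter, and both compounds remain weak at the single concentration tested. Nothing available explains this result.

On these data alone, whether an amine or a longer alkyl chain on this carbon would read any differently remains open. So does whether any group here can lift the number beyond the scatter.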